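The source may report more compounds than this note shows. Statements on the series, on what has been measured and on what is new or still open speak of the compounds shown alone.

Measured so far in an assay on Sf9 cells for inhibition of protein deacetylase HDAC6 (Homo sapiens), read by fluorescence, with a stated time of 40 min, tested at 100 nM; on this read-out higher numbers stand for more inhibition at the one concentration tested (going by the name of the read-out) and lower numbers for less inhibition:
compound 1 `Cc1ccc(-c2nc(CNc3ccc(C(=O)NO)cc3)n(-c3ccccc3)n2)cc1` — 62.2%
compound 2 `O=C(NO)c1ccc(NCc2nc(-c3ccc(Br)cc3)nn2-c2ccccc2)cc1` — 54.7%
compound 3 `O=C(O)c1ccc(NCc2nc(-c3ccccc3)nn2-c2ccccc2)cc1` — -0.4%

Compound 2 stands second highest of the three numbers. Its nearest neighbour is compound 1; the step of a number 7.5 percentage points lower from compound 1 to compound 2 (within the scatter) is within the scatter, so the two cannot be ordered. Compound 3 stands far below both; it differs from compound 2 in more than one place, a carboxylic acid in place of the hydroxamic acid and a plain phenyl in place of the bromophenyl, so its number shows only that this combination gives essentially no inhibition.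

Compound 4 `O=C(NO)c1ccc(NCc2nc(-c3ccc(Br)o3)nn2-c2ccccc2)cc1` is the next step: 5-bromofuran-2-yl in place of 4-bromophenyl on an aromatic carbon. For the measured compounds named here, no measured step touches the same place with the same kind of change. Going by the values given here, the only step at this position, from compound 1 to compound 2, exchanged one substituent on the six-membered aromatic ring of carbon only and stayed within the scatter; it gives no direction for replacing that ring itself. The hydroxamic acid is kept. The step of a number 4.7 percentage points lower from compound 2 to compound 4 (within the scatter) is therefore expected to lie within the scatter, with wider uncertainty than a substituent swap. Estimated for compound 4: 50%, range 28% to 70%.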

Compound 4, a percentage reported as inhibition, at one concentration (the size of the read-out at that concentration, not a potency): 55.8%
For compound 4 the middle estimate is 5.8 percentage points below the measured one, within the range that was stated.
By their numbers in this assay, from the lowest: compound 3; then compounds 2, 4 and 1 (each within the scatter of the next).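

In this assay the step to 5-bromofuran-2-yl gives a number 1.1 percentage points higher from compound 2 to compound 4 (within the scatter) and so extends the picture at this position from a substituent swap to an exchange of the ring itself, a five-membered aromatic ring with 1 hetero atom in place of a six-membered aromatic ring of carbon only. The comparison with the 4-methylphenyl group gives a number 6.4 percentage points lower from compound 1 to compound 4 (within the scatter) and leaves the three groups on this aromatic carbon without an order. No supporting evidence bears on why the number holds across this ring exchange.

Still open, going by these compounds, is whether a furan ring without the bromine, or a ring carrying an amine or a methoxy group, gives a number in the same range at this position. Also open, on these data alone, is how much of the low number of compound 3 belongs to its carboxylic acid alone, as that compound differs from the others in more than one place.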